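Swapping the Aryl Thioether of Compound 3 for an Aryl Ether

The source may report more compounds than this note shows. Statements on the series, on what has been measured and on what is new or still open speak of the compounds shown alone.

Compound 1 `CCCCCCNC1=C2C(=NC1=O)c1cccc3c(Sc4ccc(N)cc4)ccc2c13`: 80 nM
Compound 2 `COc1ccc(Sc2ccc3c4c(cccc24)C2=NC(=O)C(C#N)=C23)cc1`: 945 nM
Compound 3 `CCCCCCNC1=C2C(=NC1=O)c1cccc3c(Sc4ccc(OC)cc4)ccc2c13`: 206 nM

In an assay on isolated protein for binding affinity to Apoptosis regulator Bcl-2 (Homo sapiens), read by ELISA (on this read-out lower numbers stand for stronger inhibition and higher numbers for weaker inhibition), compound 3 stands second among the three numbers: compound 1 lies at 80 nM, and the step of a 2.6-fold higher number from compound 1 to compound 3 (0.41 log units; beyond the scatter) is beyond the scatter, while compound 2 sits at 945 nM, so that a 4.6-fold lower number from compound 2 to compound 3 (0.66 log units; beyond the scatter) is also beyond the scatter. Compound 4 `CCCCCCNC1=C2C(=NC1=O)c1cccc3c(Oc4ccc(C(C)C)cc4)ccc2c13` differs from compound 3 by 4-isopropylphenoxy in place of (4-methoxyphenyl)sulfanyl on an aromatic carbon. Within the data shown here, only a 2.6-fold higher number from compound 1 to compound 3 (0.41 log units; beyond the scatter) touches the same position, and it changed a single para substituent, not the linking atom; no measured pair covers the oxygen-for-sulfur exchange or the isopropyl. The expected step of a 1.2-fold higher number from compound 3 to compound 4 (0.08 log units; within the scatter) is therefore small and uncertain in direction. Compound 4 is estimated at 250 nM in this assay, within 70 nM to 900 nM.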

Compound 4, half-maximal inhibitory concentration: 184 nM
Compound 4: the middle estimate sits 1.4-fold (0.13 log units) above what was measured; the measured number falls inside the stated range.
By their numbers in this assay, from the lowest: compound 1; then compounds 4 and 3 (each within the scatter of the next); then compound 2.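

In this assay, putting 4-isopropylphenoxy in place of (4-methoxyphenyl)sulfanyl on this aromatic carbon gives a 1.1-fold lower number from compound 3 to compound 4 (0.05 log units; within the scatter), so the linking atom and the outer substituent can change together here without a shift beyond the scatter. Measured against the (4-aminophenyl)sulfanyl group, the same ether gives a 2.3-fold higher number from compound 1 to compound 4 (0.36 log units; beyond the scatter). Nothing at hand explains either result. The compounds shown leave open what the oxygen and the isopropyl each contribute on their own. They also leave open how a 4-aminophenoxy group would read at this position.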